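The compounds below may be only part of what the source reports. "The series", "measured", "known", "first", "only" and "open" are said of these compounds alone.

Measured so far:
compound 1 `CC(C)(C)c1ccc(S(=O)(=O)N[C@H]2CCN(CCNc3ccncc3)C2=O)cc1` — 14%
compound 2 `O=C1[C@@H](NS(=O)(=O)c2nc3cc(Cl)ccc3[nH]2)CCN1Cc1cc2c[nH]ccc-2n1` — 31%

In an assay on isolated protein for inhibition of coagulation factor X (Oryctolagus cuniculus), tested at 1 uM (a higher number here means more inhibition at the concentration tested (going by the name of the read-out), a lower number less inhibition), compound 2 gives the higher of the two values, and its gap to compound 1 lies beyond the usual scatter. Compound 3 `CC(C)(C)c1ccc(S(=O)(=O)N[C@H]2CCN(Cc3cc4c[nH]ccc-4n3)C2=O)cc1` carries the change (4-(tert-butyl)phenyl in place of 5-chloro-1H-benzimidazol-2-yl on a sulfonyl sulfur). Among the compounds with values here, the entering group is the one already present in compound 1, where this assay gave 14%, so a fall is expected. From compound 2 the step of a number 16 percentage points lower from compound 2 to compound 3 (beyond the scatter) is the expected size. Compound 3 is estimated at 15%, within 5% to 30%.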

Compound 3, a percentage reported as inhibition, at one concentration (the size of the read-out at that concentration, not a potency): 14%
The estimate for compound 3 lay 1 percentage points above the measured number; the range from low to high includes it.
By their numbers in this assay, from the lowest: compounds 1 and 3 (each within the scatter of the next); then compound 2.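

In this assay, the group on the sulfonyl sulfur matters when the rest of the molecule is held fixed: 4-(tert-butyl)phenyl in place of 5-chloro-1H-benzimidazol-2-yl gives a number 17 percentage points lower from compound 2 to compound 3 (beyond the scatter) for this change. With 4-(tert-butyl)phenyl in place, exchanging the group on the saturated chain carbon gives no change at the digits printed from compound 1 to compound 3 (within the scatter) here, so this assay does not separate those two groups. Nothing available explains either result.

Still open, going by these compounds, is whether the chlorine or the ring nitrogens of 5-chloro-1H-benzimidazol-2-yl go with the higher number. An unsubstituted 1H-benzimidazol-2-yl or a 5-chloroindol-2-yl on the sulfonyl sulfur would help separate the two.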